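Swapping a Methyl for Hydroxyethoxy on a Branched Side Chain

The source may report more compounds than this note shows. Statements on the series, on what has been measured and on what is new or still open speak of the compounds shown alone.

Compound 1, `CC(C)(C)c1cn(CCNc2nonc2/C(=N/O)Nc2ccc(F)c(Br)c2)nn1`: 1870 nM
Compound 2, `CCC(O)c1cn(CCNc2nonc2/C(=N/O)Nc2ccc(F)c(Br)c2)nn1`: 947 nM
Compound 3, `OCCOCc1cn(CCNc2nonc2/C(=N/O)Nc2ccc(F)c(Br)c2)nn1`: 144 nM

Of the compounds shown here, three sharing one core have been measured in an assay on isolated protein for inhibition of Indoleamine 2,3-dioxygenase 2 (Homo sapiens); a lower number here means a stronger inhibitor, a higher number a weaker inhibitor. Compound 1 gives the highest of the three numbers; compound 2 sits nearest, with a 2.0-fold lower number from compound 1 to compound 2 (0.30 log units; within the scatter), while compound 3 lies furthest, with a 13-fold lower number from compound 1 to compound 3 (1.11 log units; beyond the scatter). Between those two, a 6.6-fold lower number from compound 2 to compound 3 (0.82 log units; beyond the scatter).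

Compound 4, `CC(C)(OCCO)c1cn(CCNc2nonc2/C(=N/O)Nc2ccc(F)c(Br)c2)nn1`, has not yet been measured. It differs from compound 1 by 2-hydroxyethoxy in place of methyl on a saturated chain carbon bound to an aromatic carbon and two saturated chain carbons. Compound 3 also carries a 2-hydroxyethoxy fragment, so the steps toward it, a 13-fold lower number from compound 1 to compound 3 (1.11 log units; beyond the scatter) and a 6.6-fold lower number from compound 2 to compound 3 (0.82 log units; beyond the scatter), bear most on this change. Among the compounds with values here, compound 4 keeps two of the methyl groups of compound 1, and compound 2, which keeps more carbon at that position, gave only a 2.0-fold lower number from compound 1 to compound 2 (0.30 log units; within the scatter), so a smaller step than the one to compound 3 seems the safer expectation. A step of a 4.7-fold lower number from compound 1 to compound 4 (0.67 log units; beyond the scatter) is therefore expected. Compound 4 is estimated at 400 nM, with a range from 150 nM to 1200 nM.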

Compound 4, half-maximal inhibitory concentration: 1170 nM
The estimate for compound 4 lay 2.9-fold (0.47 log units) below the measured number, within the range that was stated.
By their numbers in this assay, from the lowest: compound 3; then compounds 2, 4 and 1 (each within the scatter of the next).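

In this assay, the 2-hydroxyethoxy fragment does not by itself bring the gain seen with compound 3: on the branched carbon it leaves compound 4 level with the tert-butyl compound (a 1.6-fold lower number from compound 1 to compound 4 (0.20 log units; within the scatter)) and with the 1-hydroxypropyl compound (a 1.2-fold higher number from compound 2 to compound 4 (0.09 log units; within the scatter)). What separates compound 4 from compound 3 is the pair of methyl groups in 1-(2-hydroxyethoxy)-1-methylethyl, and that single change gives a clear step (an 8.1-fold higher number from compound 3 to compound 4 (0.91 log units; beyond the scatter)), so the carbon bearing the fragment matters as much as the fragment itself. No measurement shown here explains this difference.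

The compounds shown leave open whether a single methyl group on that carbon would give a number nearer compound 3 or nearer compound 4. They also leave open how an amine or a carboxylic acid in place of the terminal hydroxyl would compare with compound 3.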